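Trifluoromethyl in place of ethoxy: a small step expected

A few compounds are considered here, and "the series" means these few. Any claim that something is new, unique, unknown or untested is made for them only; others in the source may bear on it.

Three compounds share one core. Compound 1 `Cc1ccc2nc(C(=O)Nc3c(F)cc(-c4cccc(F)c4)cc3F)c(C)c(C(=O)O)c2c1` gives 6.34% in a functional assay on Hep 3B2 cells (Homo sapiens) for antiproliferative activity, read by MTT assay, with a stated time of 24 h, tested at 0.14 ug/mL; on this read-out higher numbers stand for a stronger effect at the one concentration tested and lower numbers for a weaker effect. Compound 2 `CCc1ccc2nc(C(=O)Nc3c(F)cc(-c4cccc(F)c4)cc3F)c(C)c(C(=O)O)c2c1` gives 0.68% in this assay, and compound 3 `CCOc1ccc2nc(C(=O)Nc3c(F)cc(-c4cccc(F)c4)cc3F)c(C)c(C(=O)O)c2c1` gives 2.06%. Compound 3 stands within the usual scatter of both others, as a number 4.3 percentage points lower from compound 1 to compound 3 (within the scatter) and a number 1.4 percentage points higher from compound 2 to compound 3 (within the scatter) show. Compound 4 `Cc1c(C(=O)Nc2c(F)cc(-c3cccc(F)c3)cc2F)nc2ccc(C(F)(F)F)cc2c1C(=O)O` differs from compound 3 by trifluoromethyl in place of ethoxy on an aromatic carbon. Within the data shown here, no measured step brings in a trifluoromethyl; the steps that bear on this one alter the same aromatic carbon, namely a number 5.7 percentage points lower from compound 1 to compound 2 (within the scatter), a number 4.3 percentage points lower from compound 1 to compound 3 (within the scatter) and a number 1.4 percentage points higher from compound 2 to compound 3 (within the scatter), and every one of them is small. A step of no more than the scatter is therefore expected, a number 0.9 percentage points higher from compound 3 to compound 4 (within the scatter). Compound 4 is estimated at 3%, within a range of -5% to 12%.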

Compound 4, a percentage reported as inhibition, at one concentration (the size of the read-out at that concentration, not a potency): 2.13%
Compound 4: the middle estimate sits 0.9 percentage points above what was measured, and the stated range covers the measured number.
By their numbers in this assay, from the lowest: compounds 2, 3, 4 and 1 (each within the scatter of the next).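

In this assay, trifluoromethyl on this aromatic carbon gives only small steps: a number 0.1 percentage points higher from compound 3 to compound 4 (within the scatter), a number 1.5 percentage points higher from compound 2 to compound 4 (within the scatter) and a number 4.2 percentage points lower from compound 1 to compound 4 (within the scatter). The methyl, ethyl, ethoxy and trifluoromethyl compounds therefore all lie within the scatter of one another, so even this change of group leaves no measurable difference at this position. Nothing available explains this result. On these data alone, whether any group at this position can change the read-out stays open, since all four compounds give small numbers at the one concentration tested. An amine, a carboxylic acid or a longer chain on this carbon might settle that.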